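The source may report more compounds than this note shows. Statements on the series, on what has been measured and on what is new or still open speak of the compounds shown alone.

Working notes on the series. In a functional assay on PC-3 cells (Homo sapiens) for inhibition (on this read-out higher numbers stand for weaker inhibition and lower numbers for stronger inhibition), compound 1 `CCn1c(=O)/c(=C2\Sc3ccccc3N2C)s/c1=C\c1ccncc1Nc1cc(F)ccc1F` gives 1200 nM, and compound 2 `CCn1c(=O)/c(=C2\Sc3ccc(OC)cc3N2C)s/c1=C\c1ccncc1Nc1ccccc1F` gives 100 nM. Going by the values given here, on these two numbers compound 2 stands lowest, with compound 1 as its only neighbour at a clearly higher value; the two differ at more than one point, so no single-change step connects them.

Compound 3 `CCn1c(=O)/c(=C2\Sc3ccccc3N2C)s/c1=C\c1ccncc1Nc1ccccc1F` is the next member to be run in this assay. The change from compound 2 to compound 3 is hydrogen in place of methoxy on an aromatic carbon, on an aromatic carbon of the six-membered carbon ring that forms part of the fused system.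

Among the compounds with values here, no measured step isolates this change. Given that compound 1 reaches 1200 nM without the methoxy, a modest rise in the number is expected rather than no change, though it might stay within the scatter. The expected step is a 2.5-fold higher number from compound 2 to compound 3 (0.40 log units; beyond the scatter). Compound 3 is estimated at 250 nM, within 80 nM to 800 nM.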

Compound 3, half-maximal inhibitory concentration: 360 nM
Estimate against measurement, compound 3: 1.4-fold (0.16 log units) below; the range from low to high includes it.
By their numbers in this assay, from the lowest: compound 2; then compound 3; then compound 1.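

In this assay the methoxy on this carbon of the fused system can now be read on its own: hydrogen in its place gives a 3.6-fold higher number from compound 2 to compound 3 (0.56 log units; beyond the scatter) and puts the methoxy compound on the side of stronger inhibition. Compound 3 also ties compound 1 into the series by a single change, since hydrogen in place of fluoro on an aromatic carbon gives a 3.3-fold lower number from compound 1 to compound 3 (0.52 log units; beyond the scatter) and the extra fluoro goes with weaker inhibition in this pair. Nothing available explains either step.

As far as these compounds go, each change rests on one pair, so whether the methoxy step holds in the presence of the extra fluoro stays open. From the compounds shown here alone, how an ethoxy group, a hydroxy group or an amine on this same carbon would compare with methoxy also stays open.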